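Indole-pyrazole series: a single change at the carbonyl carbon

The source may hold more compounds than are shown below. What is called first, only, known or untested is meant among the compounds shown, and "the series" means these compounds.

Measured compounds:
compound 1, `CN(C(=O)CCc1ccccc1)c1ccc2[nH]c(-c3n[nH]c4ccccc34)cc2n1`, 4730 nM
compound 2, `CN(C(=O)c1ccccc1)c1ccc2[nH]c(-c3n[nH]c4cc(C#N)ccc34)cc2n1`, 6430 nM
compound 3, `COc1ccc(OC)c(S(=O)(=O)N(C)c2ccc3[nH]c(-c4n[nH]c5ccccc45)cc3n2)c1`, 840 nM

All three share the same core and differ only in the group carried by the methylated nitrogen. In a functional assay on HL-60 cells (Homo sapiens) for antiproliferative activity, read by MTT assay, with a stated time of 72 h (on this read-out lower numbers stand for stronger inhibition and higher numbers for weaker inhibition), compound 1 gives 4730 nM, the second highest of the three numbers. Compound 2 gives 6430 nM, a number within the scatter of compound 1, so the two are indistinguishable here. Compound 3 gives 840 nM, a lower number than compound 1 and separated from it by more than the scatter; it is the only one of the three that shows a clear difference from the others.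

The next compound, compound 4, `COc1ccc(NC(=O)N(C)c2ccc3[nH]c(-c4n[nH]c5ccccc45)cc3n2)cc1`, follows from compound 1 by a single change: (4-methoxyphenyl)amino in place of phenethyl on a carbonyl carbon. Among the compounds with values here, no directly comparable pair has been measured, so the expected size of the step in this assay can rest only on the three numbers above. The entering group carries a methoxy substituent as compound 3 does, but compound 3 differs from compound 1 in more than one respect, so it does not set the step.

Compound 4 is therefore expected to remain near compound 1, with an estimated step of a 1.5-fold lower number from compound 1 to compound 4 (0.17 log units; within the scatter), not beyond the scatter, and an estimated value of 3200 nM, between 1000 nM and 9500 nM.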

Compound 4, half-maximal inhibitory concentration: 7.9 nM
Compound 4: middle estimate off by 410-fold (2.61 log units), on the high side; measured number below the stated range.
By their numbers in this assay, from the lowest: compound 4; then compound 3; then compounds 1 and 2 (each within the scatter of the next).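

In this assay, within the data shown here, the single change gives a 600-fold lower number from compound 1 to compound 4 (2.78 log units; beyond the scatter), so the group on this carbonyl carbon can move the number strongly, which compounds 1, 2 and 3 could not show because no two of them differ in one place. Both phenethyl and (4-methoxyphenyl)amino carry a six-membered aromatic ring of carbon only, so the step occurs with that ring present on both sides; the counted differences are the hydrogen-bond donor and the hydrogen-bond acceptor that enter with the new group. Nothing available here bears on why the step is this large.

The step changes the linking atoms and adds the methoxy substituent at once, so the compounds shown do not separate the contribution of the amino nitrogen from that of the methoxy; an unsubstituted phenylamino group, or a benzyl group on the same carbonyl carbon, would bear on that. Also open, going by these compounds, is whether (4-methoxyphenyl)amino gives a comparable step on the core with the nitrile that compound 2 carries.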